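Swapping Fluorine for Chlorine on Two Different Cores

The source may hold more compounds than are shown below. What is called first, only, known or untested is meant among the compounds shown, and "the series" means these compounds.

Compound 1 `NS(=O)(=O)c1cccc(-c2nnc(-c3ccc(F)cc3)o2)c1` was tested in an assay on cells for inhibition of Amine oxidase [flavin-containing] B (Homo sapiens), read by fluorescence and spectrophotometry, using microsomes, with a stated time of 20 min; on this read-out lower numbers stand for stronger inhibition and higher numbers for weaker inhibition. In this assay compound 1 gives 975 nM. Compound 3 `NS(=O)(=O)c1cccc(-c2nnc(-c3ccc(Cl)cc3)o2)c1` differs from it in one place: chloro in place of fluoro on an aromatic carbon. In this assay compound 3 gives 210 nM. That single change brings a 4.6-fold lower number from compound 1 to compound 3 (0.67 log units; beyond the scatter). Compound 2 `NS(=O)(=O)c1ccc(C(=O)NNC(=O)c2ccc(F)cc2)cc1` is built on a different core, and the difference between the two cores is not broken down here. In this assay compound 2 gives only > 100000 nM, which is a limit of the assay and not a number. Compound 2 thus sits at the limit of > 100000 nM in this assay, at which 1 of the 3 values shown sits. Compound 4 `NS(=O)(=O)c1ccc(C(=O)NNC(=O)c2ccc(Cl)cc2)cc1` is compound 2 with the same change applied: chloro in place of fluoro on an aromatic carbon. The change is expected to make a number no higher from compound 2 to compound 4 (the limit leaves the size open). That expectation rests on compound 3, where the same change gave a 4.6-fold lower number from compound 1 to compound 3 (0.67 log units; beyond the scatter), and on compound 2, whose value is only the limit > 100000 nM, so that even a step of that size would be expected to leave compound 4 near the limit. For compound 4 a value of about 100000 nM is therefore expected, in a range from 30000 nM to 300000 nM.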

Compound 4, half-maximal inhibitory concentration: 11700 nM
Compound 4: middle estimate off by 8.5-fold (0.93 log units), on the high side; measured number below the stated range.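

In this assay, chloro in place of fluoro brings an at least 8.5-fold lower number from compound 2 to compound 4 (0.93 log units; beyond the scatter), so on both cores shown the same swap moves the number in the same direction, and that direction carries over from one core to the other. Compound 2 stands at > 100000 nM, which is a limit of the assay and not a number. The size of the step on this core therefore stays unfixed, and the data do not show that the swap has an equal size on both cores: the same change on two cores in this assay, a 4.6-fold lower number (0.67 log units; beyond the scatter) from compound 1 to compound 3 and an at least 8.5-fold lower number (0.93 log units; beyond the scatter) from compound 2 to compound 4; the limit leaves it open whether they differ

As far as these compounds go, only fluoro and chloro appear at this place on the aromatic ring, so it remains open how a bromo, a methyl or an amine there would read on either core. From the compounds shown here alone, two cores are also a small sample, and it remains open whether the same swap would lower the number on a third core.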